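The compounds below may be only part of what the source reports. "The series", "measured", "known", "first", "only" and "open" are said of these compounds alone.

Of the compounds shown here, three share one core and have been tested in a functional assay on CHO-K1 cells for antagonist activity at melanin-concentrating hormone receptor 1 (Homo sapiens), read by inositol phosphate accumulation; on this read-out lower numbers stand for stronger inhibition and higher numbers for weaker inhibition. Compound 1 `Cc1nc(N2CCN(C3CCCC3)CC2)nc2ccc(NC(=O)COc3ccc(Cl)cc3)cc12` gives 150 nM there. Compound 2 `CCC1(O)CCN(c2nc(C)c3cc(NC(=O)COc4ccc(OC(F)(F)F)cc4)ccc3n2)CC1` gives 59 nM in this assay, a lower number than compound 1 by more than the usual scatter. Compound 3 `Cc1nc(N2CCC(N3CCCC3)CC2)nc2ccc(NC(=O)C(C)Oc3ccc(Cl)cc3)cc12` gives 401 nM in this assay, a higher number than compound 1, again beyond the scatter. Compound 1 therefore holds the second highest of the three numbers, between the other two.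

Compound 4 `Cc1nc(N2CCN(C)CC2)nc2ccc(NC(=O)COc3ccc(Cl)cc3)cc12` has not yet been measured. It differs from compound 1 in one place: methyl in place of cyclopentyl on an amine nitrogen in a ring. Within the data shown here, no pair among the measured compounds differs in exactly this way, so no measured step guides the expectation directly.

The change is expected to raise the number, the step from compound 1 to compound 4 being estimated as a 3.3-fold higher number from compound 1 to compound 4 (0.52 log units; beyond the scatter). Compound 4 is therefore expected to give about 500 nM in this assay, with a range from 150 nM to 1600 nM.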

Compound 4, half-maximal inhibitory concentration: 3800 nM
For compound 4 the middle estimate is 7.6-fold (0.88 log units) below the measured one, outside the stated range (above it).
By their numbers in this assay, from the lowest: compound 2; then compound 1; then compound 3; then compound 4.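

In this assay, replacing cyclopentyl with methyl on the amine nitrogen of the six-membered ring brings a 25-fold higher number from compound 1 to compound 4 (1.40 log units; beyond the scatter), a large loss of inhibition. Among these compounds, this is the first measured step at this position, and it shows that the group on this nitrogen is far from a bystander: the 4-cyclopentylpiperazin-1-yl compound inhibits much more strongly than its 4-methylpiperazin-1-yl partner. Nothing available explains why the step is so large.

From the compounds shown here alone, with only these two groups compared at this nitrogen, it remains open whether inhibition strengthens gradually with group size or depends on having a ring there. Ethyl, isopropyl and cyclohexyl groups would help separate these possibilities, while a hydroxyethyl group would test whether a hydroxyl is accepted at this position.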